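The compounds below may be only part of what the source reports. "The series", "measured", "known", "first", "only" and "open" are said of these compounds alone.

The series is followed in a functional assay on MCF7 cells (Homo sapiens) for cytotoxicity, read by MTT assay, with a stated time of 72 h; a lower number here means a stronger inhibitor of growth, a higher number a weaker inhibitor of growth. Going by the values given here, compound 2, `CSc1nc(NCc2ccccc2)c2ccccc2n1`, gives 82800 nM in this assay, the highest of the two numbers measured so far. Compound 1, `CCCCC[Se]c1nc(NCc2ccc(SC)cc2)c2ccccc2n1`, gives 65000 nM in this assay, the nearest number; the values of compound 1 and compound 2 lie within the scatter of each other, so no order between them is read. Among the compounds with values here, no pair of measured compounds differs in only one place, so no single step is available as a guide. Compound 3, `CSc1ccc(CNc2nc(SC)nc3ccccc23)cc1`, awaits measurement in this assay. Compound 3 differs from compound 2 by methylsulfanyl in place of hydrogen on an aromatic carbon, para to a large group. Within the data shown here, with no comparable step measured, no change beyond the scatter is expected, and the step of a 1.2-fold lower number from compound 2 to compound 3 (0.07 log units; within the scatter) is estimated accordingly. For compound 3 the value in this assay is expected near 70000 nM, within a range from 30000 nM to 160000 nM.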

Compound 3, concentration for total growth inhibition: > 100000 nM
Compound 3 was reported as a limit (the forecaster's own chance of this, stated with the estimate: 20%); middle value at least 1.4-fold (0.15 log units) away from the limit.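

In this assay compound 3 is reported only as a limit, > 100000 nM. The series now has its first single-place steps: methylsulfanyl in place of hydrogen on an aromatic carbon, para to a large group, gives an at least 1.2-fold higher number from compound 2 to compound 3 (0.08 log units; that floor lies within the scatter), and the smaller group in place of the selenium-bearing group on an aromatic carbon gives an at least 1.5-fold higher number from compound 1 to compound 3 (0.18 log units; that floor lies within the scatter). Neither change shows a lower number, but both steps are floors, and their true size cannot be read from a value at the limit: the limit of > 100000 nM in this assay, at which 1 of the 3 values shown sits.

From the compounds shown here alone, whether an amine or a carboxylic acid at this ring position would give a number under that limit stays open. Also open, going by these compounds, is what a longer chain on the ring sulfur would do when the group at this ring position is held constant.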